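Benzylcarbamoyl to Methyl Carbamate on a Pyrazole Amide Series

The source may report more compounds than this note shows. Statements on the series, on what has been measured and on what is new or still open speak of the compounds shown alone.

Measured compounds:
Compound 1, `Cc1cc(C(=O)NCc2ccccc2)nn1Cc1cc(Cl)ccc1OCc1ccccc1`, gives > 3.7 in a physicochemical assay for lipophilicity, at pH 7.4 (on this read-out higher numbers stand for higher lipophilicity and lower numbers for lower lipophilicity), a limit of the assay and not a number.
Compound 2, `Cc1cc(NC(=O)CC(C)(C)C)nn1Cc1cc(Cl)ccc1OCc1ccccc1`, gives > 3.7 in this assay, again a limit.
Compound 3, `Cc1cc(NC(=O)C2CCOCC2)nn1Cc1cc(Cl)ccc1OCc1ccccc1`, gives > 3.7 in this assay, again a limit.

Compound 1 therefore stands only at a limit, with no number to place it against the others; (the limit of > 3.7 in this assay, at which 3 of the 3 values shown sit). The steps a step that the two limits leave unreadable from compound 1 to compound 2 and a step that the two limits leave unreadable from compound 1 to compound 3 are the ones that bear on the change considered here, but both stay unreadable, so no measured size can be carried over. Compound 4, `COC(=O)Nc1cc(C)n(Cc2cc(Cl)ccc2OCc2ccccc2)n1`, differs from compound 1 as follows: (methoxycarbonyl)amino in place of benzylcarbamoyl on an aromatic carbon. Going by the values given here, with every measured value sitting at the same limit, the account has no measured step to go on, only the counted change in which a larger group with a six-membered aromatic ring leaves and a smaller (methoxycarbonyl)amino group enters. For compound 4 the estimate in this assay is 3.5, between 2.9 and 4.1, which is expected to mean a step of a number at least 0.20 log units lower from compound 1 to compound 4 (that floor lies within the scatter) downward, though the limit on compound 1 leaves its true size open.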

Compound 4, distribution coefficient: > 3.7
Compound 4: only a limit was reported; the forecaster's own chance of this, stated with the estimate: 30%; middle value at least 0.20 log units from the limit.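

In this assay, going by these compounds alone, compound 4 gives > 3.7 as a limit of the assay and not a number, so no step to it from compound 1, compound 2 or compound 3 can be read. What the compounds shown leave open is where any of the four stands as a number, and so how large the change from benzylcarbamoyl to (methoxycarbonyl)amino is: the limit of > 3.7 in this assay, at which 4 of the 4 values shown sit.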